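A few compounds are considered here, and "the series" means these few. Any claim that something is new, unique, unknown or untested is made for them only; others in the source may bear on it.

Compound 3, `CCc1ccc(-c2cn3ccnc3c(-c3ccc4ncn(Cc5ccccc5)c4c3)n2)cc1`, gives 1.96 in a physicochemical assay for lipophilicity, using the shake flask method, in phosphate buffer, measured as octanol-water partition, with a stated time of 85 min, at pH 7.4; on this read-out higher numbers stand for higher lipophilicity and lower numbers for lower lipophilicity. Among the three compounds measured so far it holds the highest number, but its distance to compound 1, `c1cn2cc(-c3ccsc3)nc(-c3ccc4ncn(C5CCCCC5)c4c3)c2n1`, which gives 1.81, and to compound 2, `CCc1ccc(-c2cn3ccnc3c(-c3ccc4ncn(C5CCCCC5)c4c3)n2)cc1`, which gives 1.66, stays inside the scatter of the method, so the three cannot be set in order.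

Compound 4, `O=Cc1ccc(-c2cn3ccnc3c(-c3ccc4ncn(Cc5ccccc5)c4c3)n2)cc1`, differs from compound 3 in one place: formyl in place of ethyl on an aromatic carbon. The two steps measured in this series concern other exchanges. From compound 1 to compound 2 the change was a number 0.15 log units lower from compound 1 to compound 2 (within the scatter), and from compound 2 to compound 3 it was a number 0.30 log units higher from compound 2 to compound 3 (within the scatter); neither exchanges ethyl for formyl, so neither gives a direct reading for the present step. Both show that a swap of one aromatic or saturated ring for another moved the partition coefficient little. The exchange of ethyl for formyl introduces one hydrogen-bond acceptor and a double bond outside aromatic rings, and this kind of exchange is generally expected to give a clear decrease in the partition coefficient, larger than the measured steps.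

The step from compound 3 to compound 4 is therefore estimated as a number 0.96 log units lower from compound 3 to compound 4 (beyond the scatter). For compound 4 the expected value in this assay is 1, with a range from 0.4 to 1.6.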

Compound 4, partition coefficient: 1.88
For compound 4 the middle estimate is 0.88 log units below the measured one, outside the stated range (above it).
By their numbers in this assay, from the lowest: compounds 2, 1, 4 and 3 (each within the scatter of the next).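

At this place, on an aromatic carbon of a six-membered aromatic ring of carbon only and para to a large group, the exchange of ethyl for formyl gives a number 0.08 log units lower from compound 3 to compound 4 (within the scatter) in this assay. Unlike the earlier steps, which exchanged one ring group for another, this one swaps a two-carbon chain for a group with a hydrogen-bond acceptor and a double bond outside aromatic rings, and the read-out still does not separate the two compounds, so all three steps shown now lie within the scatter. This rests on a single pair, and nothing in the data shown accounts for the result.

From the compounds shown here alone, whether an amine, a carboxylic acid or a longer chain at the same place would give a step beyond the scatter remains open. Also open is whether formyl in place of ethyl would read the same with cyclohexyl rather than benzyl on the aromatic nitrogen, the background of compound 2, since the one pair shown carries benzyl there.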